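The source may hold more compounds than are shown below. What is called first, only, known or untested is meant among the compounds shown, and "the series" means these compounds.

Measured compounds:
compound 1, `Cc1ccc(C2=Nn3c(nnc3C(C)c3ccc(CC(C)C)cc3)SC2)cc1`, 5300 nM
compound 2, `COc1ccc(C2=Nn3c(nnc3C(C)c3ccc(-c4ccccc4)c(F)c3)SC2)cc1`, 3500 nM

Both numbers come from a functional assay on Hep 3B2 cells (Homo sapiens) for inhibition, read by sulforhodamine B assay, with a stated time of 72 h; a lower number here means a stronger inhibitor, a higher number a weaker inhibitor. The gap between compound 1 and compound 2 is within the usual scatter, so neither can be set apart from the other on these two values alone; compound 2 simply sits at the nearer end of a pair that does not separate.

Compound 3, `CC(c1ccc(-c2ccccc2)c(F)c1)c1nnc2n1N=C(c1ccc(Br)cc1)CS2`, is not yet measured in this assay. It differs from compound 2 in one place: bromo in place of methoxy on an aromatic carbon, para to a large group, which read one bond further out is 4-methoxyphenyl to 4-bromophenyl. For the measured compounds named here, no measured pair shows the effect of this change, and nothing among the two measured compounds speaks for a large move in either direction.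

The expected step from compound 2 to compound 3 is therefore a 1.2-fold lower number from compound 2 to compound 3 (0.07 log units; within the scatter), not beyond the scatter. Compound 3 is estimated at 3000 nM, with a range of 1200 nM to 8000 nM in this assay.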

Compound 3, half-maximal inhibitory concentration: 1500 nM
The estimate for compound 3 lay 2.0-fold (0.30 log units) above the measured number; low and high end bracket the measured number.
By their numbers in this assay, from the lowest: compound 3; then compounds 2 and 1 (each within the scatter of the next).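

In this assay, bromo in place of methoxy on an aromatic carbon, para to a large group, gives a 2.3-fold lower number from compound 2 to compound 3 (0.37 log units; beyond the scatter) (a modest step, but the only one so far that can be read in one place). The group on this carbon can therefore shift the number in this assay, which compound 1 and compound 2 could not show, as they differ in more than one place and do not separate. Nothing at hand indicates what lies behind this step.

From the compounds shown here alone, the step is read on a single background, that of compound 2, so whether it carries over to the other side chain of compound 1 remains open. Also open, going by these compounds, is how chloro, trifluoromethyl, an amine or a carboxylic acid on the same carbon would compare with bromo and methoxy.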